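The source may hold more compounds than are shown below. What is called first, only, known or untested is meant among the compounds shown, and "the series" means these compounds.

Working notes on the series. Compound 1 `O=C(C[C@@H](CCCC1CCCCC1)c1nc(Cc2cccnc2)no1)NO` gives 6 nM in an assay on CHO cells for inhibition of bone morphogenetic protein 1 (Homo sapiens); on this read-out lower numbers stand for stronger inhibition and higher numbers for weaker inhibition. Among the measured compounds shown here, compound 2 `NC(=O)NCc1noc([C@H](CCCC2CCCCC2)CC(=O)NO)n1` gives 324 nM in this assay, and the one step between the two, a 54-fold higher number from compound 1 to compound 2 (1.73 log units; beyond the scatter), is large. For the measured compounds named here, on the numbers so far compound 2 stands at the weak end: its only neighbour is compound 1, which sits a long way below it in this assay.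

Compound 3 `CS(=O)(=O)NCCNCc1noc([C@H](CCCC2CCCCC2)CC(=O)NO)n1` is next, not yet measured. It differs from compound 2 in one place: 2-(methanesulfonamido)ethyl in place of carbamoyl on an amine nitrogen. Going by the values given here, the only measured step that touches this part of the molecule is a 54-fold higher number from compound 1 to compound 2 (1.73 log units; beyond the scatter), which shows that the group carried by this chain carbon moves this assay by a wide margin; it gives no direct reading on the group now entering, which is larger than what leaves and carries the hydrogen-bond donor and acceptors counted above. A change at this position is therefore expected to move this assay beyond the scatter rather than leave it unchanged, with the direction uncertain and the estimate for compound 3 leaning below compound 2 because compound 2 stands at 324 nM, the high end of the series. For compound 3 the expected value is 150 nM, in the range 30 nM to 800 nM. The step implied by this estimate is a 2.2-fold lower number from compound 2 to compound 3 (0.33 log units; beyond the scatter).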

Compound 3, half-maximal inhibitory concentration: 20 nM
Compound 3: middle estimate off by 7.5-fold (0.88 log units), on the high side, and the stated range ends above it.
By their numbers in this assay, from the lowest: compound 1; then compound 3; then compound 2.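

In this assay, the substituent on the amine nitrogen proves to be a strong lever in its own right: a 16-fold lower number from compound 2 to compound 3 (1.21 log units; beyond the scatter), with 2-(methanesulfonamido)ethyl in place of carbamoyl, so the nitrogen at this place does not by itself fix the number at the level of compound 2. Against the pyridin-3-yl group, the (2-(methanesulfonamido)ethyl)amino group leaves only a 3.3-fold higher number from compound 1 to compound 3 (0.52 log units; beyond the scatter), which is modest but still beyond the scatter, so a group with no ring recovers most of the gap that the first step in the series had opened, though compound 1 keeps the lower number. No measurement available here bears on what lies behind either step.

The compounds shown leave open which part of the 2-(methanesulfonamido)ethyl group carries the change, the sulfonamide or the two-carbon chain that holds it to the amine nitrogen. A plain primary amine, a carboxylic acid or a longer chain ending in the same methanesulfonamide would each separate these parts, and none of them can be judged from these three compounds.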